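The source may hold more compounds than are shown below. What is called first, only, known or untested is meant among the compounds shown, and "the series" means these compounds.

Measured compounds in this series:

- compound 1, `CC(C)CCc1c(F)c(C2=NS(=O)(=O)c3ccccc3N2)c(O)c2ccccc12`, 12000 nM
- compound 2, `CC(C)CCc1c(F)c(C2=NS(=O)(=O)c3cc(NS(C)(=O)=O)ccc3N2)c(O)c2ccccc12`, > 100000 nM
- compound 3, `COc1c(C2=NS(=O)(=O)c3ccccc3N2)cc(CCC(C)C)c2ccccc12`, 13000 nM

In an ADME assay on Huh-7 cells (Homo sapiens) for cytotoxicity (on this read-out lower numbers stand for higher toxicity in this test and higher numbers for lower toxicity in this test), compound 1 gives 12000 nM. Compound 2 reaches only the limit of this assay, > 100000 nM, so its value is a limit and not a number. Compound 3 gives 13000 nM in this assay; against compound 1 it stands an at least 8.3-fold higher number from compound 1 to compound 2 (0.92 log units; beyond the scatter) apart in the other direction only within scatter, so no order between compound 1 and compound 3 is claimed.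

The change from compound 1 to compound 2 is methanesulfonamido in place of hydrogen on an aromatic carbon and produces an at least 8.3-fold higher number from compound 1 to compound 2 (0.92 log units; beyond the scatter); the shift ends at the limit described by the limit of > 100000 nM in this assay, at which 1 of the 3 values shown sits.

Compound 4, `COc1c(C2=NS(=O)(=O)c3cc(NS(C)(=O)=O)ccc3N2)cc(CCC(C)C)c2ccccc12`, is not yet measured. It arises from compound 3 by methanesulfonamido in place of hydrogen on an aromatic carbon, the same change as from compound 1 to compound 2, at the same place. The difference between the two cores of compound 1 and compound 3 is not broken down here.

Compound 4 is expected to show a 7.7-fold higher number from compound 3 to compound 4 (0.89 log units; beyond the scatter) in this assay, resting on compound 1 and compound 2 giving an at least 8.3-fold higher number from compound 1 to compound 2 (0.92 log units; beyond the scatter). Compound 4 is therefore estimated at 100000 nM, between 40000 nM and 250000 nM, with a fair chance that only a limit is reported.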

Compound 4, half-maximal cytotoxic concentration: 51000 nM
For compound 4 the middle estimate is 2.0-fold (0.29 log units) above the measured one; the range from low to high includes it.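

In this assay, methanesulfonamido in place of hydrogen on an aromatic carbon of the core of compound 3 gives a 3.9-fold higher number from compound 3 to compound 4 (0.59 log units; beyond the scatter), so the direction seen on the core of compound 1 also holds on this second core. Compound 2 gives > 100000 nM, which is a limit and not a number. The two pairs therefore show a shared direction on two cores, but they do not show a shared size, and two cores are too few to establish a general rule for this series: the same change on two cores in this assay, an at least 8.3-fold higher number (0.92 log units; beyond the scatter) from compound 1 to compound 2 and a 3.9-fold higher number (0.59 log units; beyond the scatter) from compound 3 to compound 4; the limit leaves it open whether they differ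

The compounds shown leave open whether another group on the same aromatic carbon, such as an amine, a carboxylic acid or a sulfonamide with a longer chain, would move the number in the same way. They also leave open how the difference between the core of compound 1 and the core of compound 3 bears on the size of the step, since only these two cores carry the change.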